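Trimming the Side Chain of Compound 2

This account rests on a few compounds, and the source may have more. Where it says the series, first, only, none or still open, it means among the compounds named here.

Compound 1 `CC[C@H](c1ccc(C(=O)O)c(Oc2cccc(Cl)c2)c1OC)N1CCC[C@H](n2cc(C)c(=O)[nH]c2=O)C1`: 0.015
Compound 2 `Cc1cn([C@H]2CCCN([C@H](CC(C)C)c3ccc(C(=O)O)c(Oc4cccc(Cl)c4)c3F)C2)c(=O)[nH]c1=O`: 0.013

In an ADME assay on a cell-free system (plasma, Homo sapiens) for protein binding, using equilibrium dialysis, with a stated time of 5 h, tested at 10 uM (on this read-out higher numbers stand for a larger free fraction and lower numbers for a smaller free fraction), compound 2 gives 0.013 and compound 1 gives 0.015, two values within the scatter of each other. Compound 3 `CC[C@H](c1ccc(C(=O)O)c(Oc2cccc(Cl)c2)c1F)N1CCC[C@H](n2cc(C)c(=O)[nH]c2=O)C1` differs from compound 2 by one change, methyl in place of isopropyl on a saturated chain carbon, two bonds along the chain from an amine nitrogen in a ring and an aromatic carbon: methyl in place of isopropyl on a saturated chain carbon, or isobutyl to ethyl when cut one bond further out. Among the measured compounds shown here, no measured pair shows the effect of this change in this assay. A small rise in the free fraction is expected, though not one beyond the scatter. The expected step is a 1.5-fold higher number from compound 2 to compound 3 (0.16 log units; within the scatter). For compound 3 the estimated value is 0.019, with an expected range from 0.011 to 0.034.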

Compound 3, unbound fraction: < 0.01
Compound 3 gave a limit, no number (the forecaster's own chance of this, stated with the estimate: 1%); middle value at least 1.9-fold (0.27 log units) from the limit.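

In this assay, compound 3 stands at a limit of the assay, not at a number. At the saturated chain carbon, methyl in place of isopropyl therefore gives only a floor, an at least 1.3-fold lower number from compound 2 to compound 3 (0.11 log units; that floor lies within the scatter), and fluoro in place of methoxy on the aromatic carbon gives another, an at least 1.5-fold lower number from compound 1 to compound 3 (0.17 log units; that floor lies within the scatter). Neither change gave a higher number, and the full size of both steps cannot be read because compound 3 sits at the limit: the limit of < 0.01 in this assay, at which 1 of the 3 values shown sits.

The compounds shown leave open how a hydroxyl group or a cyclopropyl ring on that chain carbon would alter the free fraction.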